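The source may hold more compounds than are shown below. What is called first, only, known or untested is meant among the compounds shown, and "the series" means these compounds.

Measured so far in a functional assay on T47D cells (Homo sapiens) for cytotoxicity, read by CCK-8 assay, with a stated time of 4 days; on this read-out lower numbers stand for stronger inhibition and higher numbers for weaker inhibition:
compound 1 `Oc1ccc(-c2cc(-c3ccccc3O)cc(-c3ccccc3O)n2)cc1`, 960 nM;
compound 2 `Oc1ccc(-c2cc(-c3cccc(O)c3)cc(-c3ccccc3O)n2)cc1`, 50000 nM;
compound 3 `Oc1ccc(-c2cc(-c3ccccc3O)nc(-c3ccccc3O)c2)cc1`, 18300 nM.

Compound 3 stands second highest of the three numbers in this assay; its nearest neighbour is compound 2, with a higher number, and the furthest is compound 1, with a markedly lower one, both gaps beyond the scatter. Within the data shown here, the only step that changes a hydroxyphenyl group is the one from compound 1 to compound 2, a 52-fold higher number from compound 1 to compound 2 (1.72 log units; beyond the scatter), and it points firmly towards weaker inhibition when the 2-hydroxyphenyl pattern is given up.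

Compound 4 `Oc1ccc(-c2cc(-c3ccc(O)cc3)nc(-c3ccccc3O)c2)cc1` differs from compound 3 as follows: 4-hydroxyphenyl in place of 2-hydroxyphenyl on an aromatic carbon. Among the measured compounds shown here, no pair here has the 4-hydroxyphenyl entering in place of the 2-hydroxyphenyl on that carbon, so the step from compound 1 to compound 2 is the nearest guide. On that basis a shift towards a higher number in this assay is expected, though smaller, since compound 3 already gives a high number. The step from compound 3 to compound 4 is estimated at a 2.7-fold higher number from compound 3 to compound 4 (0.44 log units; beyond the scatter). Compound 4 is therefore expected to give about 50000 nM, between 15000 nM and 160000 nM.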

Compound 4, half-maximal inhibitory concentration: 50000 nM
For compound 4 middle estimate and measured number coincide at the digits printed, within the range that was stated.
By their numbers in this assay, from the lowest: compound 1; then compound 3; then compounds 2 and 4 (each within the scatter of the next).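

In this assay, placing the 4-hydroxyphenyl group next to the ring nitrogen in place of 2-hydroxyphenyl costs a modest step (a 2.7-fold higher number from compound 3 to compound 4 (0.44 log units; beyond the scatter)), so this carbon also responds to the change of hydroxyphenyl pattern, though less than the large step seen when compound 4 is set against compound 1 (a 52-fold higher number from compound 1 to compound 4 (1.72 log units; beyond the scatter)). The 3-hydroxyphenyl and 4-hydroxyphenyl patterns are not separated by the one comparison available (no change at the digits printed from compound 2 to compound 4 (within the scatter)), so among the listed compounds the loss appears with either group, and neither compound 2 nor compound 4 goes against it. No supporting measurement bears on what lies behind these steps.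

Among these compounds, whether the 2-hydroxyphenyl group matters through its hydroxyl itself remains open, since the series holds no compound with a methoxy group, an amine or a carboxylic acid in that place on the phenyl ring. Also open, from the compounds shown here alone, is whether compound 1, at 960 nM, would keep its number in this assay with a fluorine atom or an unsubstituted phenyl group in place of any one of its hydroxyphenyl groups.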